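Amino to methoxy on two related cores

The source may hold more compounds than are shown below. What is called first, only, known or untested is meant among the compounds shown, and "the series" means these compounds.

Measured so far:
compound 1 `Nc1ccccc1/C=C/c1ccccc1O` gives 27 ug/mL in an ADME assay on HEK293 cells (Homo sapiens) for inhibition, read by MTT assay, with a stated time of 2 days; on this read-out higher numbers stand for weaker inhibition and lower numbers for stronger inhibition.
compound 2 `COc1ccccc1/C=C/c1ccccc1O` gives 15 ug/mL in this assay.
compound 3 `Nc1cccc(/C=C/c2cccc(O)c2)c1` gives only a limit of the assay, > 100 ug/mL, in this assay.

Compound 1 and compound 2 differ in one place, (methoxy in place of amino on an aromatic carbon), and this gave a 1.8-fold lower number from compound 1 to compound 2 (0.26 log units; within the scatter). Compound 4 `COc1cccc(/C=C/c2cccc(O)c2)c1` has not yet been measured; it differs from compound 3 by methoxy in place of amino on an aromatic carbon. This is the same kind of change, though the place is not the same: in compound 1 the group sits ortho to a group of 9 heavy atoms, in compound 3 meta to a group of 9 heavy atoms. The difference between the two cores is not broken down here. Compound 3 stands at the limit of > 100 ug/mL in this assay, at which 1 of the 3 values shown sits. For compound 4 a step that the limit leaves unreadable from compound 3 to compound 4 is expected, because a 1.8-fold lower number from compound 1 to compound 2 (0.26 log units; within the scatter) lay within the scatter. Compound 4 is estimated at 110 ug/mL, between 45 ug/mL and 300 ug/mL, most likely again only a limit.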

Compound 4, half-maximal inhibitory concentration: 19 ug/mL
Beside the measured number, compound 4's estimate is 5.8-fold (0.76 log units) above it, and the stated range ends above it.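

In this assay, methoxy in place of amino gave an at least 5.2-fold lower number from compound 3 to compound 4 (0.72 log units; beyond the scatter). The change therefore did not carry over in size from one core to the other: the same change on two cores in this assay, a 1.8-fold lower number (0.26 log units; within the scatter) from compound 1 to compound 2 and an at least 5.2-fold lower number (0.72 log units; beyond the scatter) from compound 3 to compound 4, at least 2.9-fold (0.46 log units) apart, beyond the scatter of two such steps. This does not show why the two steps differ, and the second has no exact size, as compound 3 gives only a limit of the assay: the limit of > 100 ug/mL in this assay, at which 1 of the 4 values shown sits.

The two cores differ from each other in more than one place, and the compounds shown do not say which difference sets the steps apart. They also leave open how an ethoxy group or a dimethylamino group would behave in place of amino on either core.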